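From 3-carboxyphenyl to 4-carboxyphenyl on a shared core

The source may report more compounds than this note shows. Statements on the series, on what has been measured and on what is new or still open speak of the compounds shown alone.

In a functional assay on CLL cells (Homo sapiens) for cytotoxicity, read by MTT assay, with a stated time of 48 h (a lower number here means that less compound is needed, a higher number that more compound is needed for the effect), compound 1 `C=C(CC)C(=O)c1ccc(OCC(=O)NCCCN2CCCC2=O)c(Cl)c1Cl` gives 13800 nM and compound 2 `C=C(CC)C(=O)c1ccc(OCC(=O)Nc2cccc(C(=O)O)c2)c(Cl)c1Cl` gives 20600 nM so these two numbers sit within the scatter of each other and compound 2 cannot be ranked apart from compound 1. The measured step of a 1.5-fold higher number from compound 1 to compound 2 (0.17 log units; within the scatter) is the exchange of 3-(2-oxopyrrolidin-1-yl)propyl for 3-carboxyphenyl on an amide-type nitrogen.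

Compound 3 `C=C(CC)C(=O)c1ccc(OCC(=O)Nc2ccc(C(=O)O)cc2)c(Cl)c1Cl` has not yet been measured. It carries 4-carboxyphenyl in place of 3-carboxyphenyl on an amide-type nitrogen and thus has the same atoms as compound 2, joined differently. For the measured compounds named here, no measured pair shows this exchange itself. Going by the values given here, only one measured step bears on it, and only indirectly, since it changed a group on the same nitrogen: a 1.5-fold higher number from compound 1 to compound 2 (0.17 log units; within the scatter) stayed within the scatter. As far as these compounds go, on that slender evidence, no step beyond the scatter is expected in this assay and the direction remains open. The expected step is a 1.1-fold lower number from compound 2 to compound 3 (0.06 log units; within the scatter) and no more than that is anticipated. For compound 3 the estimated value is 18000 nM with an expected range from 9000 nM to 38000 nM as the likely outcome.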

Compound 3, half-maximal effective concentration: 5000 nM
Compound 3: the middle estimate sits 3.6-fold (0.56 log units) above what was measured; measured number below the stated range.
By their numbers in this assay, from the lowest: compound 3; then compounds 1 and 2 (each within the scatter of the next).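

In this assay, 4-carboxyphenyl in place of 3-carboxyphenyl on the amide-type nitrogen gives a 4.1-fold lower number from compound 2 to compound 3 (0.61 log units; beyond the scatter), so two groups with the same atoms, joined differently, can be told apart at this place, which the earlier exchange on the same nitrogen did not show. The exchange of 3-(2-oxopyrrolidin-1-yl)propyl for 4-carboxyphenyl also goes beyond the scatter, with a 2.8-fold lower number from compound 1 to compound 3 (0.44 log units; beyond the scatter), which makes 4-carboxyphenyl the group with the lowest number of the three on this nitrogen, although both new steps are modest. No evidence is at hand to account for the difference between the two carboxyphenyl groups.

The compounds shown leave open whether the lower number depends on the carboxylic acid itself, since no 4-substituted phenyl group on this nitrogen carries a methyl ester, an amine or a primary amide instead. They also leave open whether a longer chain between the phenyl ring and the carboxylic acid would keep, lower or raise the number seen with 4-carboxyphenyl on the shared core.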